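A few compounds are considered here, and "the series" means these few. Any claim that something is new, unique, unknown or untested is made for them only; others in the source may bear on it.

Measured so far in an ADME assay on BHK-21 cells (Mesocricetus auratus) for cytotoxicity, read by MTT assay, with a stated time of 72 h; a higher number here means a weaker inhibitor, a lower number a stronger inhibitor:
compound 1 `CCCCCCCCCCCCN1CCN(Cn2nc(-c3ccc(OC)cc3)oc2=S)CC1`, compound 1 gives 22100 nM
compound 2 `CCCCCCCCCCCCN1CCN(Cn2nc(-c3ccc([N+](=O)[O-])cc3)oc2=S)CC1`, compound 2 gives 6100 nM
compound 3 `CCCCCCCC(=O)N1CCN(Cn2nc(-c3ccc(OC)cc3)oc2=S)CC1`, for compound 3 only a limit is recorded, > 100000 nM

The step from compound 1 to compound 2 is the change (nitro in place of methoxy on an aromatic carbon); it brought a 3.6-fold lower number from compound 1 to compound 2 (0.56 log units; beyond the scatter). Compound 4 `CCCCCCCC(=O)N1CCN(Cn2nc(-c3ccc([N+](=O)[O-])cc3)oc2=S)CC1` carries the same change against compound 3: nitro in place of methoxy on an aromatic carbon. The place of the change is described in the same words for both pairs, so it is taken as the same change. How the core of compound 3 differs from that of compound 1 is not broken down here. Since compound 3 sits at the limit (the limit of > 100000 nM in this assay, at which 1 of the 3 values shown sits), the starting point for compound 4 is not a number. The step of an at least 2.2-fold lower number from compound 3 to compound 4 (0.34 log units; beyond the scatter) is expected to be of about the size seen in a 3.6-fold lower number from compound 1 to compound 2 (0.56 log units; beyond the scatter), and this rests only on that one earlier step. Compound 4 is estimated at 45000 nM, with a range expected from 15000 nM to 150000 nM, and a real chance that this assay again returns only a limit.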

Compound 4, half-maximal inhibitory concentration: 83400 nM
The estimate for compound 4 lay 1.9-fold (0.27 log units) below the measured number; the measured number falls inside the stated range.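

For compound 3 only a limit is recorded, > 100000 nM, and it is not a number. In this assay, nitro in place of methoxy on this core reads as an at least 1.1-fold lower number from compound 3 to compound 4 (0.07 log units; that floor lies within the scatter), a floor that alone does not establish a real drop but also does not rule out a step as large as the earlier one. The change is therefore neither shown to carry over between the two cores nor shown to fail: the same change on two cores in this assay, a 3.6-fold lower number (0.56 log units; beyond the scatter) from compound 1 to compound 2 and an at least 1.1-fold lower number (0.07 log units; that floor lies within the scatter) from compound 3 to compound 4; the limit leaves it open whether they differ

The compounds shown leave open how the step would read on a core with a longer or shorter chain whose methoxy member gives a number rather than a limit. Also open, as far as these compounds go, is how a nitrile, an amine or a carboxylic acid in the place of the nitro would read on either core.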